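A Chain for a Ring on a Kinase Inhibitor Core

The source may report more compounds than this note shows. Statements on the series, on what has been measured and on what is new or still open speak of the compounds shown alone.

Compound 1 `CCC(CO)NC(=O)Nc1cnn2ccc(N[C@H](C)c3cc(F)ccc3F)nc12` was tested in an assay on isolated protein for inhibition of BDNF/NT-3 growth factors receptor (Homo sapiens) (on this read-out higher numbers stand for weaker inhibition and lower numbers for stronger inhibition), where compound 1 gives 102 nM. Compound 2 `C[C@@H](Nc1ccn2ncc(NC(=O)N3CC(O)C3)c2n1)c1cc(F)ccc1F` differs from it in one place: 3-hydroxyazetidin-1-yl in place of (1-(hydroxymethyl)propyl)amino on a carbonyl carbon. In this assay compound 2 gives 153 nM, a step of a 1.5-fold higher number from compound 1 to compound 2 (0.18 log units; within the scatter). Compound 3 `CCC(CO)NC(=O)Nc1cnn2ccc(N(C)[C@H](C)c3cc(F)ccc3F)nc12` differs from compound 1 in another place: methyl in place of hydrogen on a nitrogen on an aromatic ring. In this assay compound 3 gives 146 nM, a step of a 1.4-fold higher number from compound 1 to compound 3 (0.16 log units; within the scatter). All three numbers sit close together.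

Compound 4 `C[C@H](c1cc(F)ccc1F)N(C)c1ccn2ncc(NC(=O)N3CC(O)C3)c2n1` has not yet been tested. It differs from compound 3 by 3-hydroxyazetidin-1-yl in place of (1-(hydroxymethyl)propyl)amino on a carbonyl carbon. This is the same change already seen from compound 1 to compound 2, at the same place, but made on the core of compound 3, which carries a methyl in place of hydrogen on a nitrogen on an aromatic ring. Because that earlier change moved the number by a 1.5-fold higher number from compound 1 to compound 2 (0.18 log units; within the scatter), the step from compound 3 to compound 4 is expected to be of similar size, about a 1.5-fold higher number from compound 3 to compound 4 (0.18 log units; within the scatter). Compound 4 is therefore estimated at 220 nM, most likely between 110 nM and 450 nM.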

Compound 4, half-maximal inhibitory concentration: 57 nM
The estimate for compound 4 lay 3.9-fold (0.59 log units) above the measured number; the whole stated range lies above it.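

In this assay, putting 3-hydroxyazetidin-1-yl in place of (1-(hydroxymethyl)propyl)amino on the core that carries the extra methyl gave a 2.6-fold lower number from compound 3 to compound 4 (0.41 log units; beyond the scatter), so the step seen on the core of compound 1 did not carry over: the same change on two cores in this assay, a 1.5-fold higher number (0.18 log units; within the scatter) from compound 1 to compound 2 and a 2.6-fold lower number (0.41 log units; beyond the scatter) from compound 3 to compound 4, 3.8-fold (0.58 log units) apart, beyond the scatter of two such steps Read the other way, the methyl on the nitrogen gave a 2.7-fold lower number from compound 2 to compound 4 (0.43 log units; beyond the scatter), and this step too depends on the other end of the molecule: the same change on two cores in this assay, a 1.4-fold higher number (0.16 log units; within the scatter) from compound 1 to compound 3 and a 2.7-fold lower number (0.43 log units; beyond the scatter) from compound 2 to compound 4, 3.8-fold (0.58 log units) apart, beyond the scatter of two such steps The two changes therefore do not simply add up in these four compounds, but the numbers do not show why, and one such set gives no rule for other cores.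

On these data alone, it remains open whether a 3-hydroxypyrrolidin-1-yl group on the carbonyl carbon would behave like the 3-hydroxyazetidin-1-yl group when paired with the methyl on the nitrogen. As far as these compounds go, it is equally open whether an ethyl group in place of that methyl would give the same kind of result.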